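Swapping a dichlorophenyl pattern in a gastric cancer cell assay

The source may report more compounds than this note shows. Statements on the series, on what has been measured and on what is new or still open speak of the compounds shown alone.

Of the compounds shown here, three have been tested in a functional assay on MGC-803 cells (Homo sapiens) for inhibition, read by MTT assay, with a stated time of 72 h, tested at 10 uM; on this read-out lower numbers stand for less inhibition of growth and higher numbers for more inhibition of growth at the one concentration tested. Compound 1, `O=C(/C=C/c1ccc(Cl)c(Cl)c1)/C=C/c1ccccc1Oc1ncnc2ccc(Cl)cc12`, gives 56.7%. Compound 2, `O=C(/C=C/c1ccc(Oc2ncnc3ccc(Cl)cc23)cc1)/C=C/c1ccc(Cl)c(Cl)c1`, gives 50.5%, and compound 3, `O=C(/C=C/c1ccc(Oc2ncnc3ccc(Cl)cc23)cc1)/C=C/c1cccc(Cl)c1Cl`, gives 68.5%. Compound 3 differs from compound 2 in one place: 2,3-dichlorophenyl in place of 3,4-dichlorophenyl on a double-bonded chain carbon bound to a double-bonded chain carbon. That change brought a number 18 percentage points higher from compound 2 to compound 3 (beyond the scatter). Compound 1 and compound 2 have the same atoms joined differently, but the difference between their two cores is not broken down here; their values in this assay lie within the scatter of each other.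

Compound 4, `O=C(/C=C/c1ccccc1Oc1ncnc2ccc(Cl)cc12)/C=C/c1cccc(Cl)c1Cl`, has not yet been measured. It stands to compound 1 as compound 3 stands to compound 2: 2,3-dichlorophenyl in place of 3,4-dichlorophenyl on a double-bonded chain carbon bound to a double-bonded chain carbon. The place of the change is the same in both pairs, so it is the same change seen a second time. Because the earlier change gave a number 18 percentage points higher from compound 2 to compound 3 (beyond the scatter), a step of similar size is expected for compound 4, namely a number 16.3 percentage points higher from compound 1 to compound 4 (beyond the scatter). This rests on a single prior example, so it is held loosely. Compound 4 is estimated at 73%, with a range from 60% to 85%.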

Compound 4, percent growth inhibition at one concentration: 76.5%
For compound 4 the middle estimate is 3.5 percentage points below the measured one, and the stated range covers the measured number.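

In this assay, putting 2,3-dichlorophenyl in place of 3,4-dichlorophenyl on the core of compound 1 gave a number 19.8 percentage points higher from compound 1 to compound 4 (beyond the scatter), so the change carried over to a second core with its direction intact. The two steps also agree in size: the same change on two cores in this assay, a number 18 percentage points higher (beyond the scatter) from compound 2 to compound 3 and a number 19.8 percentage points higher (beyond the scatter) from compound 1 to compound 4, 1.8 percentage points apart, within the scatter of two such steps. This shows that, for these two cores, which have the same atoms joined differently, the change in the dichlorophenyl pattern behaved alike and its size did not depend on which of the two cores carried it, but two pairs at the one concentration tested in a single cell line do not establish a rule for other cores, nor do they explain why this pattern gives more inhibition of growth.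

The compounds shown leave open whether other dichlorophenyl patterns would give a similar step. They also leave open what a single chlorine, a methoxy group, a trifluoromethyl group or an amine on that phenyl ring would do on either core.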